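A cytotoxicity limit and the step to compound 3

This account rests on a few compounds, and the source may have more. Where it says the series, first, only, none or still open, it means among the compounds named here.

Measured in an ADME assay on MT4 cells (Homo sapiens) for cytotoxicity, read by MTT assay, with a stated time of 5 days; a lower number here means that less compound is tolerated, a higher number that more compound is tolerated:
Compound 1 `COc1cc2nc([S+]([O-])CC(=O)Nc3ccccc3C(F)(F)F)nc(Nc3c(Cl)cc(/C=C/C#N)cc3Cl)c2cc1OC` gives > 192000 nM (a limit)
Compound 2 `COc1cc2nc([S+]([O-])CC(=O)Nc3ccccc3C#N)nc(Nc3c(Cl)cc(/C=C/C#N)cc3Cl)c2cc1OC` gives > 206000 nM (a limit)

For the measured compounds named here, compound 2 has no exact number in this assay because its reading of > 206000 nM is a limit, and the only other value shown is a limit too. Going by the values given here, the one measured step is a step that the two limits leave unreadable from compound 1 to compound 2 and it offers no size to carry forward. That step, cyano in place of trifluoromethyl on an aromatic carbon, also differs from the change now in question.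

Compound 3 `COc1cc2nc([S+]([O-])CC(=O)Nc3ccc(C)cc3)nc(Nc3c(Cl)cc(/C=C/C#N)cc3Cl)c2cc1OC` is still unmeasured and carries 4-methylphenyl in place of 2-cyanophenyl on an amide-type nitrogen. Among the compounds with values here, no measured step covers this change. Compound 2 with its limit of > 206000 nM is therefore the only reference, so no step beyond the scatter is expected in this assay and no direction can be named. The expected step is an at least 1.1-fold lower number from compound 2 to compound 3 (0.05 log units; that floor lies within the scatter) and it remains an estimate only. Compound 3 is estimated at 180000 nM with an expected range from 40000 nM to 215000 nM. Compound 3 may again give only a limit.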

Compound 3, half-maximal cytotoxic concentration: 32200 nM
Beside the measured number, compound 3's estimate is 5.6-fold (0.75 log units) above it, outside the stated range (below it).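

In this assay the group on the amide-type nitrogen proves able to shift the read-out: 4-methylphenyl in place of 2-cyanophenyl gives an at least 6.3-fold lower number from compound 2 to compound 3 (0.80 log units; beyond the scatter), and 4-methylphenyl in place of 2-(trifluoromethyl)phenyl gives an at least 5.9-fold lower number from compound 1 to compound 3 (0.77 log units; beyond the scatter), while compound 3 is the only compound shown with an exact reading. The first of these steps gives only a floor for its size because compound 2 stands at a limit: the limit of > 206000 nM in this assay, at which 1 of the 3 values shown sits. The second also gives only a floor for its size because compound 1 stands at a limit: the limit of > 192000 nM in this assay, at which 1 of the 3 values shown sits.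

The step between compound 1 and compound 2 cannot be read, so the compounds shown do not tell whether 2-cyanophenyl and 2-(trifluoromethyl)phenyl differ in this assay, nor how far either lies from compound 3. They also leave open whether the lower number follows from the methyl group of 4-methylphenyl or from the loss of the nitrile or trifluoromethyl group, a question that an unsubstituted phenyl group on the same nitrogen would bear on directly.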